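This account rests on a few compounds, and the source may have more. Where it says the series, first, only, none or still open, it means among the compounds named here.

Measured compounds:
compound 1 `COc1cn([C@@H]2O[C@H](COP(=O)(O)OP(=O)(O)O)[C@@H](O)[C@H]2O)c(=O)[nH]c1=O`, in an in vitro functional assay on 1321-N1 cells for agonist activity at P2Y purinoceptor 2 (Homo sapiens), read by calcium flux; on this read-out lower numbers stand for an effect already at smaller amounts and higher numbers for an effect only at larger amounts of compound: "not active" (no number reported)
compound 2 `O=c1[nH]c(=O)n([C@@H]2O[C@H](COP(=O)(O)OP(=O)(O)OP(=O)(O)O)[C@@H](O)[C@H]2O)cc1Br`, in this assay: 2060 nM

Compound 2 carries the only numerical result in this assay; compound 1 is simply recorded as "not active" (no number reported) without a number, so the two values cannot be set against each other. Compound 3 `O=c1[nH]c(=O)n([C@@H]2O[C@H](COP(=O)(O)OP(=O)(O)OP(=O)(O)O)[C@@H](O)[C@H]2O)cc1F` differs from compound 2 by fluoro in place of bromo on an aromatic carbon. Going by the values given here, no step between measured compounds is available for this change. The change is expected to stay within the scatter, with no clear direction. Compound 3 is therefore estimated at about 1800 nM, with a range from 600 nM to 5500 nM. The implied step, a 1.1-fold lower number from compound 2 to compound 3 (0.06 log units; within the scatter), is expected to be small.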

Compound 3, half-maximal effective concentration: 6000 nM
For compound 3 the middle estimate is 3.3-fold (0.52 log units) below the measured one; measured number outside the range, above it.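

In this assay, the two halogens are not interchangeable on this aromatic carbon: fluoro in place of bromo gives a 2.9-fold higher number from compound 2 to compound 3 (0.46 log units; beyond the scatter), a modest step beyond the usual scatter. Going by these compounds alone, this is the first reading of a change at this position, and it shows that the number responds to the group held there. Nothing measured here accounts for the step.

Going by these compounds, it remains open how chloro, iodo or a methyl group on the same carbon would read. Within the data shown here, compound 1 has no number, so no step to it can be read.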